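This account rests on a few compounds, and the source may have more. Where it says the series, first, only, none or still open, it means among the compounds named here.

Compound 1 `O=C(CCCCCCCCCCCc1ccccc1)CC(=O)N[C@H]1CCOC1=O`: 33000 nM
Compound 2 `O=C(CCCCCCCc1ccccc1)CC(=O)N[C@H]1CCOC1=O`: 42000 nM

Both values come from a functional assay on NCI-H630 cells (Homo sapiens) for cytotoxicity, read by sulforhodamine B assay, with a stated time of 5 days; on this read-out lower numbers stand for stronger inhibition and higher numbers for weaker inhibition. Compound 2 stands level with compound 1 on this read-out, the two numbers lying within the scatter of each other. Compound 3 `O=C(CCCCCCCCCc1ccccc1)CC(=O)N[C@H]1CCOC1=O`, not yet measured, carries phenethyl in place of phenyl on a saturated chain carbon, seven bonds along the chain from a carbonyl carbon. Its chain is longer than that of compound 2 and shorter than that of compound 1. With compound 1 at 33000 nM and compound 2 at 42000 nM, the two measured chains show no separation, so no change beyond the scatter is expected in this assay. The estimated step is a 1.2-fold lower number from compound 2 to compound 3 (0.07 log units; within the scatter), which is expected to stay within the scatter. For compound 3 the estimated value is 36000 nM, with an expected range from 18000 nM to 75000 nM.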

Compound 3, half-maximal inhibitory concentration: 16000 nM
Beside the measured number, compound 3's estimate is 2.3-fold (0.35 log units) above it; the measured number lies below the stated range.
By their numbers in this assay, from the lowest: compound 3; then compounds 1 and 2 (each within the scatter of the next).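

Within this assay, lengthening the chain of compound 2 gives a 2.6-fold lower number from compound 2 to compound 3 (0.42 log units; beyond the scatter) and shortening the chain of compound 1 gives a 2.1-fold lower number from compound 1 to compound 3 (0.31 log units; beyond the scatter), so the two steps meet at the same compound from opposite directions. The chain terminus at this position therefore does affect the read-out, which compounds 1 and 2 alone did not show: they sit within the scatter of each other, while the intermediate chain of compound 3 gives the lowest number of the three, and the response does not run steadily with length. No data here explain this dependence on chain length.

From the compounds shown here alone, the shape of the response between these chains remains open, since three lengths cannot show how narrow the dip is. Also open, going by these compounds, is whether a chain ending in a carboxylic acid or an amine, in place of the phenyl ring, would keep the lower number.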